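From urea to amide in a cell inhibition series

A few compounds are considered here, and "the series" means these few. Any claim that something is new, unique, unknown or untested is made for them only; others in the source may bear on it.

Measured compounds:
Compound 1 `COc1cc(Cl)cc(-c2nn(-c3cccc(NC(=O)Nc4ccc(Cl)c(C(F)(F)F)c4)c3)cc2-c2ccncc2)c1` — in a functional assay on M14 cells (Homo sapiens) for inhibition, read by sulforhodamine B assay, with a stated time of 48 h, tested at 0.1 uM (a lower number here means a stronger effect, a higher number a weaker effect of the compound at the concentration tested), compound 1 gives 96%.
Compound 2 `COc1cc(Cl)cc(-c2nn(-c3cccc(NC(=O)Nc4ccc(Cl)c(Cl)c4)c3)cc2-c2ccncc2)c1` — in this assay compound 2 gives 100%.
Compound 3 `COc1cc(Cl)cc(-c2nn(-c3cccc(NC(=O)Nc4cccc(C(F)(F)F)c4)c3)cc2-c2ccncc2)c1` — in this assay compound 3 gives 93%.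

The three measured compounds sit close together. The step of a number 4 percentage points higher from compound 1 to compound 2 (within the scatter) and the step of a number 3 percentage points lower from compound 1 to compound 3 (within the scatter) are both within the scatter, as is the step of a number 7 percentage points lower from compound 2 to compound 3 (within the scatter); compound 3 therefore cannot be set apart from compound 1 or compound 2 on these numbers.

Compound 4 `COc1cc(Cl)cc(-c2nn(-c3cccc(NC(=O)c4cccc(C(F)(F)F)c4)c3)cc2-c2ccncc2)c1` differs from compound 3 in this way: 3-(trifluoromethyl)phenyl in place of (3-(trifluoromethyl)phenyl)amino on a carbonyl carbon. Within the data shown here, none of the measured steps touches the carbonyl carbon or its amide-type nitrogen; they only exchange substituents on the outer aromatic ring, and all of them stayed within the scatter. Among the measured compounds shown here, there is thus no measured step that bears directly on the change from compound 3 to compound 4, and the only guide is that the whole series has so far stayed in a narrow band in this assay. For compound 4 the expected step is a number 2 percentage points higher from compound 3 to compound 4 (within the scatter), that is, none beyond the scatter. Compound 4 is therefore estimated at 95%, with a range from 82% to 105%.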

Compound 4, a percentage reported as activity, at one concentration (the size of the read-out at that concentration, not a potency): 93%
Estimate against measurement, compound 4: 2 percentage points above, and the stated range covers the measured number.
By their numbers in this assay, from the lowest: compounds 3, 4, 1 and 2 (each within the scatter of the next).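

In this assay, the change at the carbonyl carbon from (3-(trifluoromethyl)phenyl)amino to 3-(trifluoromethyl)phenyl gives no change at the digits printed from compound 3 to compound 4 (within the scatter) and so shows, as the earlier ring substituent steps could not, that the read-out holds when the amide-type link itself is altered and the hydrogen-bond donor of the leaving group is gone. The wider steps, a number 7 percentage points lower from compound 2 to compound 4 (within the scatter) and a number 3 percentage points lower from compound 1 to compound 4 (within the scatter), which alter that link and the outer ring substituents together, leave compound 4 equally inseparable from the two other ureas. Nothing at hand offers an explanation for this flat result.

The compounds shown leave open whether any group on this carbonyl carbon can move the number beyond the scatter in this assay. A carboxylic acid, a morpholine or a longer alkyl chain there would test this.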